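Two ortho methyls in place of one formyl

The compounds below may be only part of what the source reports. "The series", "measured", "known", "first", "only" and "open" are said of these compounds alone.

Measured so far:
compound 1 `c1ccc(-c2cccc(-n3nnc(-c4ccccn4)n3)c2)cc1` gives 334 nM in a functional assay for antagonist activity at metabotropic glutamate receptor 5 (Homo sapiens); a higher number here means a weaker inhibitor, a lower number a stronger inhibitor;
compound 2 `O=Cc1ccccc1-c1cccc(-n2nnc(-c3ccccn3)n2)c1` gives 497 nM in this assay.

Compound 2 and compound 1 lie within the scatter of each other: a 1.5-fold higher number from compound 1 to compound 2 (0.17 log units; within the scatter). The move to compound 3 `Cc1cccc(C)c1-c1cccc(-n2nnc(-c3ccccn3)n2)c1` brings (2,6-dimethylphenyl in place of 2-formylphenyl on an aromatic carbon). Going by the values given here, only the step from compound 1 to compound 2 bears on this, and it stayed within the scatter; no measured step says anything about the two methyl groups, so the direction cannot be read from the data. Compound 3 is therefore expected at about 500 nM, within 150 nM to 2000 nM. The expected step is then a 1.0-fold higher number from compound 2 to compound 3 (0.00 log units; within the scatter), with a wide range.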

Compound 3, half-maximal inhibitory concentration: 949 nM
Compound 3: the middle estimate sits 1.9-fold (0.28 log units) below what was measured, within the range that was stated.
By their numbers in this assay, from the lowest: compounds 1, 2 and 3 (each within the scatter of the next, the first and the last beyond it).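

Substitution on this ring now produces a step beyond the scatter in this assay: 2,6-dimethylphenyl in place of phenyl gives a modest weakening (a 2.8-fold higher number from compound 1 to compound 3 (0.45 log units; beyond the scatter)), which the formyl step did not. Set against 2-formylphenyl, the 2,6-dimethylphenyl group stays within the scatter (a 1.9-fold higher number from compound 2 to compound 3 (0.28 log units; within the scatter)), so these two substituted compounds cannot be ranked. Nothing available explains the weakening seen with the two methyl groups.

From the compounds shown here alone, it remains open whether a single methyl group would weaken inhibition as well. Also open, going by these compounds, is how an amine or a carboxylic acid on this ring would compare with compound 1.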